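From 4-Bromophenyl to 2,4-Dichlorophenyl

The compounds below may be only part of what the source reports. "The series", "measured", "known", "first", "only" and "open" are said of these compounds alone.

In a functional assay on L1210 cells (Mus musculus) for cytotoxicity, read by MTT assay, with a stated time of 24 h (on this read-out lower numbers stand for stronger inhibition and higher numbers for weaker inhibition), compound 3 `COc1cc(C(=O)/C=C/c2ccc(Br)cc2)cc(OC)c1OC` gives > 100000 nM as its reading, and that is a limit of the assay and not a number. Two relatives on the shared core do give numbers. Compound 1 `COc1cc(C(=O)/C=C/c2ccc(Cl)c(Cl)c2)cc(OC)c1OC` reads 44000 nM and compound 2 `COc1cc(C(=O)/C=C/c2c(Cl)cccc2Cl)cc(OC)c1OC` reads 50500 nM with their dichlorophenyl groups.

The unmeasured compound 4 `COc1cc(C(=O)/C=C/c2ccc(Cl)cc2Cl)cc(OC)c1OC` differs from compound 3 in one place. The change is 2,4-dichlorophenyl in place of 4-bromophenyl on a double-bonded chain carbon bound to a double-bonded chain carbon and nothing else in the molecule moves.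

Going by the values given here, three measured steps bear on this change. The two dichlorophenyl compounds sit close together, with a 1.1-fold higher number from compound 1 to compound 2 (0.06 log units; within the scatter) between them. Putting 4-bromophenyl in place of a dichlorophenyl group gives an at least 2.2-fold higher number from compound 1 to compound 3 (0.35 log units; beyond the scatter) in one case and an at least 1.9-fold higher number from compound 2 to compound 3 (0.29 log units; that floor lies within the scatter) in the other, and both of these are only floors.

The 2,4-dichlorophenyl group itself has not been measured. Still, compound 4 carries a dichlorophenyl group, as compound 1 does at 44000 nM and compound 2 does at 50500 nM in the same series. A reading near that pair is therefore expected, which means a move towards stronger inhibition. In this assay the expected change is an at least 2.0-fold lower number from compound 3 to compound 4 (0.30 log units; that floor lies within the scatter) and no more than modest in size. Compound 4 is estimated at 50000 nM as a middle value, with an expected range from 25000 nM to 100000 nM around it.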

Compound 4, half-maximal inhibitory concentration: 52500 nM
For compound 4 the middle estimate is 1.1-fold (0.02 log units) below the measured one; the measured number falls inside the stated range.
By their numbers in this assay, from the lowest: compounds 1, 2 and 4 (each within the scatter of the next). At a limit, above all of these: compound 3.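

In this assay, moving from one dichlorophenyl group to another at this place on the chain changes little, with a 1.0-fold higher number from compound 2 to compound 4 (0.02 log units; within the scatter) and a 1.2-fold higher number from compound 1 to compound 4 (0.08 log units; within the scatter), so the 2,4-dichlorophenyl, 2,6-dichlorophenyl and 3,4-dichlorophenyl groups cannot be ranked, and compound 1, compound 2 and compound 4 now form a group of three with no order among them. The change from 4-bromophenyl to 2,4-dichlorophenyl gives an at least 1.9-fold lower number from compound 3 to compound 4 (0.27 log units; that floor lies within the scatter), which adds a third dichlorophenyl compound whose number lies under the reading for the bromo compound, although this step is only a floor. That floor rests on compound 3, whose reading is a limit and not a number: the limit of > 100000 nM in this assay, at which 1 of the 4 values shown sits.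

From the compounds shown here alone, how far compound 3 really lies from the three dichlorophenyl compounds stays open, and with it the question of whether the size of the step is modest or much larger. A 4-chlorophenyl group would separate the kind of halogen from the number of halogens on the ring, and an amine or a carboxylic acid on that ring would show whether a group other than a halogen reads differently at this place.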